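A few compounds are considered here, and "the series" means these few. Any claim that something is new, unique, unknown or untested is made for them only; others in the source may bear on it.

Measured so far in an assay on cells for inhibition of Palmitoleoyl-protein carboxylesterase NOTUM variant C330S (Homo sapiens), read by fluorescence, with a stated time of 40 min; a higher number here means a weaker inhibitor, a lower number a stronger inhibitor:

Compound 1 `O=C(O)C1CCN(c2ccccc2Cl)C1` — compound 1 gives 19000 nM
Compound 2 `Cc1cc(C(=O)O)c(C)n1-c1ccccc1F` — compound 2 gives 3300 nM
Compound 3 `Cc1cc(C(=O)O)c(C)n1-c1cccc(Cl)c1F` — compound 3 gives 380 nM

Compound 1 stands highest of the three; compound 2 is closer to it and compound 3 furthest, both gaps lying beyond the usual scatter. The difference between the core of compound 1 and the core of compound 2 is not broken down here.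

Within the core of compound 2, the change to compound 3 is chloro in place of hydrogen on an aromatic carbon; it brought an 8.7-fold lower number from compound 2 to compound 3 (0.94 log units; beyond the scatter).

Compound 4 `O=C(O)C1CCN(c2cc(Cl)ccc2Cl)C1` is not yet measured in this assay. It arises from compound 1 by chloro in place of hydrogen on an aromatic carbon. This is the same kind of change as from compound 2 to compound 3, not the same: there the entering chloro sat ortho to a fluoro group and meta to a large group, whereas here it sits meta to a group of 8 heavy atoms and para to a chloro group.

The step from compound 1 to compound 4 is expected to be a 3.8-fold lower number from compound 1 to compound 4 (0.58 log units; beyond the scatter), smaller than the measured one because an 8.7-fold lower number from compound 2 to compound 3 (0.94 log units; beyond the scatter) was seen on a different core. Compound 4 is estimated at 5000 nM, between 2000 nM and 12000 nM.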

Compound 4, half-maximal inhibitory concentration: 7900 nM
Beside the measured number, compound 4's estimate is 1.6-fold (0.20 log units) below it; low and high end bracket the measured number.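

In this assay, chloro in place of hydrogen on an aromatic carbon of the core of compound 1 brought a 2.4-fold lower number from compound 1 to compound 4 (0.38 log units; beyond the scatter) and so lowered the number on this core, as the same kind of change did on the core of compound 2. The direction carried over from one core to the other, but the size did not: the same change on two cores in this assay, an 8.7-fold lower number (0.94 log units; beyond the scatter) from compound 2 to compound 3 and a 2.4-fold lower number (0.38 log units; beyond the scatter) from compound 1 to compound 4, 3.6-fold (0.56 log units) apart, beyond the scatter of two such steps. The two steps differ both in the core and in where the chloro enters, here meta to a group of 8 heavy atoms and para to a chloro group, so they cannot show whether the core or the place sets the size, and two pairs give no rule for any further core.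

The compounds shown leave open what step the core of compound 1 would give with the chloro in the place it holds in compound 3. They also leave open whether a bromo or methoxy group entering at the same place as in compound 4 would lower the number as the chloro does.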